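The source may hold more compounds than are shown below. What is called first, only, known or untested is meant among the compounds shown, and "the series" means these compounds.

The three compounds measured so far, with their values in a functional assay on CHO cells for agonist activity at Free fatty acid receptor 1 (Homo sapiens), read by FLIPR and calcium flux, tested at 1 uM; a higher number here means that more compound is needed for the effect, a lower number that less compound is needed:

Compound 1, `Cc1ccc(OCc2nnc(C(=O)Nc3ccc(CCC(=O)O)cc3)s2)c(C)c1`: 2540 nM
Compound 2, `O=C(O)CCc1ccc(NC(=O)c2nnc(COc3cccc(C(F)(F)F)c3)s2)cc1`: 3090 nM
Compound 3, `Cc1cccc(OCc2nnc(C(=O)Nc3ccc(CCC(=O)O)cc3)s2)c1`: 3260 nM

Compound 3 gives the highest of the three numbers, but the steps that lead to it are small: a 1.1-fold higher number from compound 2 to compound 3 (0.02 log units; within the scatter) and a 1.3-fold higher number from compound 1 to compound 3 (0.11 log units; within the scatter), both within the scatter, so compound 3 cannot be set apart from the other two.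

The next compound, compound 4, is `CCc1ccc(OCc2nnc(C(=O)Nc3ccc(CCC(=O)O)cc3)s2)cc1`. It has not yet been measured. It differs from compound 3 in one place: 4-ethylphenyl in place of 3-methylphenyl on an oxygen on a saturated carbon. The three measured steps all exchange the aromatic group on that same oxygen, and none of them moved the number beyond the scatter: a 1.2-fold higher number from compound 1 to compound 2 (0.09 log units; within the scatter), a 1.3-fold higher number from compound 1 to compound 3 (0.11 log units; within the scatter), a 1.1-fold higher number from compound 2 to compound 3 (0.02 log units; within the scatter). With no evidence that this position shifts the read-out, compound 4 is expected to land close to compound 3, giving an estimated step of a 1.1-fold lower number from compound 3 to compound 4 (0.04 log units; within the scatter). Compound 4 is therefore estimated at 3000 nM, within a range of 1500 nM to 6500 nM.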

Compound 4, half-maximal effective concentration: 1170 nM
For compound 4 the middle estimate is 2.6-fold (0.41 log units) above the measured one; the whole stated range lies above it.
By their numbers in this assay, from the lowest: compound 4; then compounds 1, 2 and 3 (each within the scatter of the next).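

Among the compounds shown here, the aromatic group on the oxygen on a saturated carbon turns out not to be silent in this assay after all: 4-ethylphenyl brings a 2.8-fold lower number from compound 3 to compound 4 (0.45 log units; beyond the scatter) and a 2.6-fold lower number from compound 2 to compound 4 (0.42 log units; beyond the scatter) and also a 2.2-fold lower number from compound 1 to compound 4 (0.34 log units; beyond the scatter) and each of these modest steps lies beyond the scatter, which none of the exchanges among the earlier compounds did. Compound 4 therefore stands apart from the other three, with the lowest number of the set, while those three remain within the scatter of one another. No measurement at hand explains this change.

The compounds shown leave open whether the gain belongs to the ethyl group itself or to where it sits on the ring, a question that 4-methylphenyl and 3-ethylphenyl would address. They also leave open how a longer chain, such as 4-propylphenyl, or an amine on that ring would read.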